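This account rests on a few compounds, and the source may have more. Where it says the series, first, only, none or still open, it means among the compounds named here.

In an assay on HEK293 cells for positive allosteric modulation of metabotropic glutamate receptor 5 (Homo sapiens), read by FLIPR (on this read-out higher numbers stand for an effect only at larger amounts of compound and lower numbers for an effect already at smaller amounts), compound 3 `Cc1cccc(-c2noc(C3CN(C(=O)C4CCC(C(F)(F)F)CC4)C3)n2)c1` gives 1000 nM, the second highest of the three numbers recorded. Its nearest neighbour is compound 2 `O=C(C1CCC(C(F)(F)F)CC1)N1CC(c2nc(-c3cccc(F)c3)no2)C1`, which in this assay gives 680 nM; the step of a 1.5-fold higher number from compound 2 to compound 3 (0.17 log units; within the scatter) stays within the scatter. Compound 1 `CC1CCC(C(=O)N2CC(c3nc(-c4cccc(Cl)c4)no3)C2)CC1` gives 1500 nM in this assay, and that number likewise lies within the scatter of compound 3. Compound 4 `O=C(C1CCC(C(F)(F)F)CC1)N1CC(c2nc(-c3cccc(Cl)c3)no2)C1` has not yet been measured. It differs from compound 3 in one place: chloro in place of methyl on an aromatic carbon. Within the data shown here, the only measured step that bears on this change is the swap of fluoro for methyl on the same aromatic carbon, a 1.5-fold higher number from compound 2 to compound 3 (0.17 log units; within the scatter), which did not move the number beyond the scatter. Compound 1 carries the same chloro group as compound 4 but also differs elsewhere, so it offers no direct comparison. Compound 4 is therefore expected to show a step of a 1.1-fold lower number from compound 3 to compound 4 (0.05 log units; within the scatter) that does not exceed the scatter. The estimate for compound 4 in this assay is 900 nM, with a range from 400 nM to 2200 nM.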

Compound 4, half-maximal effective concentration: 1000 nM
The estimate for compound 4 lay 1.1-fold (0.05 log units) below the measured number; the measured number falls inside the stated range.
By their numbers in this assay, from the lowest: compounds 2, 3, 4 and 1 (each within the scatter of the next, the first and the last beyond it).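

At the aromatic carbon meta to a large group, compound 4 adds chloro to fluoro and methyl on an otherwise unchanged structure: in this assay there is no change at the digits printed from compound 3 to compound 4 (within the scatter) and a 1.5-fold higher number from compound 2 to compound 4 (0.17 log units; within the scatter), so the three groups cannot be told apart here. Compound 4 also opens a one-place comparison at the saturated ring carbon, where trifluoromethyl in place of methyl gives a 1.5-fold lower number from compound 1 to compound 4 (0.18 log units; within the scatter), so that swap also leaves the number within the scatter. Nothing available here accounts for these results.

From the compounds shown here alone, whether an amine, a carboxylic acid or a methoxy group on this aromatic carbon would move the number beyond the scatter remains open. So does the effect of a longer chain in place of trifluoromethyl on the saturated ring carbon.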